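Trimming a Methoxy Group from a Weak Growth Inhibitor

This account rests on a few compounds, and the source may have more. Where it says the series, first, only, none or still open, it means among the compounds named here.

Three compounds share a common core and were tested in a functional assay on DU-145 cells (Homo sapiens) for inhibition, read by trypan blue exclusion, with a stated time of 96 h; on this read-out higher numbers stand for weaker inhibition of growth and lower numbers for stronger inhibition of growth. Compound 1 `COc1ccc(/C=C(/Sc2ccc(Br)cc2)C(=O)c2ccc(Br)cc2)cc1` gives 25000 nM in this assay, and compound 2 `COc1cc(/C=C(/SCc2ccc(Br)cc2)C(=O)c2ccc(Br)cc2)cc([N+](=O)[O-])c1O` gives 25000 nM. Compound 3 `O=C(/C(=C\c1ccc(F)cc1F)Sc1ccc(Br)cc1)c1ccc(Cl)cc1` stands apart with 1000 nM. On these numbers compound 2 is level with compound 1 at the digits shown, and the two together hold the highest values of the three. The gap between compound 2 and compound 3 is wide and lies well beyond the scatter of repeated measurements, while the gap between compound 2 and compound 1 lies within it.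

Compound 4 `O=C(/C(=C\c1ccc(O)c([N+](=O)[O-])c1)SCc1ccc(Br)cc1)c1ccc(Br)cc1` has not yet been measured. It differs from compound 2 in one place: hydrogen in place of methoxy on an aromatic carbon. The methoxy group leaves and a hydrogen enters on the six-membered aromatic ring of carbon only, at the carbon ortho to the hydroxy group and meta to the nitro group.

Among the measured compounds shown here, no measured pair in this set shows what removing a methoxy group does here, so the size of the step is uncertain. Given that compound 2 gives 25000 nM, the step from compound 2 to compound 4 is expected to be small, a 1.3-fold lower number from compound 2 to compound 4 (0.10 log units; within the scatter), with no clear direction beyond the scatter. Compound 4 is therefore estimated at 20000 nM, within a range of 8000 nM to 50000 nM.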

Compound 4, concentration for 50% growth inhibition: 10000 nM
Beside the measured number, compound 4's estimate is 2.0-fold (0.30 log units) above it, within the range that was stated.
By their numbers in this assay, from the lowest: compound 3; then compound 4; then compounds 1 and 2 (each within the scatter of the next).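

Among the compounds shown here, compound 2 and compound 4 form the first pair in this set that differs in one place only, so the effect of this change can now be read directly: removing the methoxy group gives a 2.5-fold lower number from compound 2 to compound 4 (0.40 log units; beyond the scatter) in this assay. The methoxy group at this position is therefore not needed for growth inhibition in this pair, and replacing it with hydrogen makes inhibition modestly stronger rather than weaker. No available data bear on why the number moves in this direction.

Going by these compounds, it remains open whether hydrogen is the best choice at this carbon, ortho to the hydroxy group, or merely one of several groups that would work; an ethoxy group or an amine at the same place would show how the read-out responds to a larger group or a different kind of atom. On these data alone, it also remains open whether removing the methoxy group would give a similar step if other parts of the shared core were changed.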